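Solubility of valerate esters of a methoxypurine riboside

This account rests on a few compounds, and the source may have more. Where it says the series, first, only, none or still open, it means among the compounds named here.

Measured compounds:
compound 1, `CCCCC(=O)OC[C@H]1O[C@@H](n2cnc3c(OC)ncnc32)[C@@H](OC(=O)CCCC)[C@@H]1OC(=O)CCCC`, 21000 nM
compound 2, `CCCCC(=O)O[C@H]1[C@H](OC(=O)CCCC)[C@@H](CO)O[C@H]1n1cnc2c(OC)ncnc21`, 694000 nM

In a physicochemical assay for solubility, in phosphate buffer (a lower number here means a less soluble compound, a higher number a more soluble compound), compound 1 gives 21000 nM, the lower of the two numbers; compound 2 gives 694000 nM. Within the data shown here, the single measured step, a 33-fold higher number from compound 1 to compound 2 (1.52 log units; beyond the scatter), comes from hydrogen in place of butylcarbonyl on an oxygen on a saturated carbon.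

Compound 3, `CCCCC(=O)OC[C@H]1O[C@@H](n2cnc3c(OC)ncnc32)[C@@H](OC(=O)CCCC)[C@@H]1O`, is not yet measured. It differs from compound 1 by hydrogen in place of butylcarbonyl on an oxygen on a saturated carbon whose other neighbours are a saturated ring carbon; cut one bond further out, (butylcarbonyl)oxy to hydroxy. The same kind of change, at a different oxygen, gave a 33-fold higher number from compound 1 to compound 2 (1.52 log units; beyond the scatter), so a rise in this assay is expected for compound 3, as a 19-fold higher number from compound 1 to compound 3 (1.28 log units; beyond the scatter). Compound 3 is therefore estimated at 400000 nM, with a range of 100000 nM to 1500000 nM.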

Compound 3, solubility: 1300000 nM
Compound 3: the middle estimate sits 3.3-fold (0.51 log units) below what was measured; measured number inside the range.
By their numbers in this assay, from the lowest: compound 1; then compounds 2 and 3 (each within the scatter of the next).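

In this assay, the oxygen on a saturated carbon whose other neighbours are a saturated ring carbon also responds strongly to hydrogen in place of butylcarbonyl, with a 62-fold higher number from compound 1 to compound 3 (1.79 log units; beyond the scatter) on this change. The step of a 33-fold higher number from compound 1 to compound 2 (1.52 log units; beyond the scatter) had shown a large rise at only one oxygen; these two steps now show it at two different oxygens of the same triester, so within these compounds the rise is not tied to a single site. Nothing at hand explains the rise at either oxygen.

Still open, as far as these compounds go, is how the third ester oxygen responds to the same change, and whether removing two butylcarbonyl groups from compound 1 would add to the rise. Also open, from the compounds shown here alone, is how a shorter acetyl group, a longer chain or an ester carrying an amine would read at these oxygens.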